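A urea replaces the amide on the shared core

The compounds below may be only part of what the source reports. "The series", "measured", "known", "first", "only" and "open" are said of these compounds alone.

The three measured compounds share a core in which an ethoxy-bearing ring is joined to a second ring that carries one variable group. Compound 1 `CCNS(=O)(=O)c1cccc(-c2ccc(OCC)cc2)c1` carries an ethylsulfamoyl group, and in an assay on COS-7 cells for inhibition of patatin-like phospholipase domain-containing protein 2 (Mus musculus) (on this read-out higher numbers stand for weaker inhibition and lower numbers for stronger inhibition), compound 1 gives 200000 nM. Compound 2 `CCCCOC(=O)c1cccc(-c2ccc(OCC)cc2)c1` carries a butoxycarbonyl group in its place; in this assay compound 2 gives 100000 nM, which is a 2.0-fold lower number from compound 1 to compound 2 (0.30 log units; within the scatter). Compound 3 `CCOc1ccc(-c2cccc(C(=O)NC)c2)cc1` carries a methylcarbamoyl group. In this assay compound 3 gives only a limit, > 200000 nM, not a number. The steps that lead to it are a number no lower from compound 1 to compound 3 (the limit leaves the size open) and an at least 2.0-fold higher number from compound 2 to compound 3 (0.30 log units; that floor lies within the scatter). Compound 3 therefore stands at the edge of what this assay can report, at the limit of > 200000 nM in this assay, at which 1 of the 3 values shown sits.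

Compound 4 `CCOc1ccc(-c2cccc(NC(=O)N(C)C)c2)cc1` changes the same position once more: (dimethylcarbamoyl)amino in place of methylcarbamoyl on an aromatic carbon. The two steps that bear on this position, a number no lower from compound 1 to compound 3 (the limit leaves the size open) and an at least 2.0-fold higher number from compound 2 to compound 3 (0.30 log units; that floor lies within the scatter), are both small or of unreadable size, and none of the three groups tried there moved the number beyond the scatter. Among the compounds with values here, no measured step shows a change at this position that pulls the number down clearly. Compound 4 is therefore expected to give 200000 nM, within a range from 60000 nM to 400000 nM. The step from compound 3 that this estimate means is expected to be a number no higher from compound 3 to compound 4 (the limit leaves the size open), which would again most likely leave compound 4 reported only as a limit.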

Compound 4, half-maximal inhibitory concentration: 70000 nM
Compound 4: the middle estimate sits 2.9-fold (0.46 log units) above what was measured, within the range that was stated.
By their numbers in this assay, from the lowest: compounds 4, 2 and 1 (each within the scatter of the next, the first and the last beyond it).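

Within the data shown here, at this position, the (dimethylcarbamoyl)amino group of compound 4 gives the first readable step in this assay that lies beyond the scatter: a 2.9-fold lower number from compound 1 to compound 4 (0.46 log units; beyond the scatter). The step against the methylcarbamoyl group is also beyond the scatter, an at least 2.8-fold lower number from compound 3 to compound 4 (0.45 log units; beyond the scatter), but it gives only a floor, since compound 3 is reported as a limit and not a number: the limit of > 200000 nM in this assay, at which 1 of the 4 values shown sits. The change is not clear against every group, as a 1.4-fold lower number from compound 2 to compound 4 (0.15 log units; within the scatter) leaves compound 2 and compound 4 inseparable in this assay, so the (dimethylcarbamoyl)amino group stands apart from the ethylsulfamoyl and methylcarbamoyl groups but not from the butoxycarbonyl group.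

The compounds shown leave open which part of the (dimethylcarbamoyl)amino group accounts for these steps, a question that an acetylamino group or a urea with a single methyl on its outer nitrogen at the same place could help to settle. Going by these compounds, it also remains open whether a simple amine or a carboxylic acid at this position would give a number clearly lower than those seen so far.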